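This account rests on a few compounds, and the source may have more. Where it says the series, first, only, none or still open, it means among the compounds named here.

In a functional assay on NCI-H520 cells (Homo sapiens) (a higher number here means a weaker inhibitor of growth, a lower number a stronger inhibitor of growth), three compounds have been measured so far. Compound 1 (`O=S(=O)(/C=C/c1ccc(C(F)(F)F)cc1F)Cc1ccc(Nc2ncnc3ccccc23)cc1`) gives 100000 nM and compound 2 (`O=S(=O)(/C=C/c1ccc(C(F)(F)F)cc1F)Cc1ccc(Nc2ncnc3ccc(Br)cc23)cc1`) gives 40000 nM. Their difference is bromo in place of hydrogen on an aromatic carbon, which brings a 2.5-fold lower number from compound 1 to compound 2 (0.40 log units; beyond the scatter). Compound 3 (`O=S(=O)(/C=C/c1ccc(Cl)cc1Cl)Cc1ccc(Nc2ncnc3cc(Cl)ccc23)cc1`) gives 76000 nM, a value within the scatter of both compound 1 and compound 2.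

Compound 4 (`O=S(=O)(/C=C/c1ccc(C(F)(F)F)cc1F)Cc1ccc(Nc2ncnc3cc(Cl)ccc23)cc1`) has not yet been measured. It differs from compound 3 by one change: 2-fluoro-4-(trifluoromethyl)phenyl in place of 2,4-dichlorophenyl on a double-bonded chain carbon bound to a double-bonded chain carbon. Among the compounds with values here, the 2-fluoro-4-(trifluoromethyl)phenyl group that enters is already carried by compound 1 and compound 2, but no measured pair isolates this exchange. Within the data shown here, the only measured step, a 2.5-fold lower number from compound 1 to compound 2 (0.40 log units; beyond the scatter), concerns a different change and offers no more than a sense of scale, and a modest one. With that group in place, compound 1 at 100000 nM and compound 2 at 40000 nM both remain weak growth inhibitors, much like compound 3. The expected result is therefore a 1.1-fold lower number from compound 3 to compound 4 (0.04 log units; within the scatter), a step estimated to stay within the scatter. Compound 4 is estimated at 70000 nM, with an expected range from 32000 nM to 120000 nM.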

Compound 4, concentration for 50% growth inhibition: > 100000 nM
Compound 4: only a limit was reported (the forecaster's own chance of this, stated with the estimate: 15%); at least 1.4-fold (0.15 log units) between middle value and limit.
By their numbers in this assay, from the lowest: compounds 2, 3 and 1 (each within the scatter of the next, the first and the last beyond it).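

In this assay, compound 4 gives only a limit of the assay, > 100000 nM. Within the data shown here, exchanging the halogen-bearing phenyl group on the chain produces an at least 1.3-fold higher number from compound 3 to compound 4 (0.11 log units; that floor lies within the scatter), so this exchange, now isolated for the first time, brings no gain in growth inhibition, though its floor is too small to establish a loss. With the 2-fluoro-4-(trifluoromethyl)phenyl group held constant, replacing the bromo-bearing group on a nitrogen on an aromatic ring with the chloro-bearing one gives an at least 2.5-fold higher number from compound 2 to compound 4 (0.39 log units; beyond the scatter), which shows that the halogen-bearing part of the molecule can separate two compounds even when the exchange at the double-bonded chain carbon does not, while the step that adds chloro gives a number no lower from compound 1 to compound 4 (the limit leaves the size open), whose size cannot be read, because it runs into the same boundary: the limit of > 100000 nM in this assay, at which 1 of the 4 values shown sits.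

Going by these compounds, it remains open whether a phenyl group carrying an amine or a carboxylic acid on the double-bonded chain carbon would give a clearly lower number. Also open, on these data alone, is what a methoxy group would do in place of the bromo of compound 2.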